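Series notes: bromo for allyloxy on the core of compound 2

The compounds below may be only part of what the source reports. "The series", "measured", "known", "first", "only" and "open" are said of these compounds alone.

Compound 1 `CCCNNC(=O)c1ccc(CNC(=O)c2ccc3cnccc3c2)cc1`, compound 2 `C=CCOc1ccc2oc(C(=O)NCc3ccc(C(=O)NNCCC)cc3)cc2c1` and compound 3 `CCCNNC(=O)c1ccc(CNC(=O)c2cc3cc(OC)ccc3[nH]2)cc1` share a common core and differ only at one end of the molecule. In an assay on isolated protein for inhibition of protein deacetylase HDAC6 (Homo sapiens), read by fluorescence, with a stated time of 2 h (a lower number here means a stronger inhibitor, a higher number a weaker inhibitor), compound 1 gives > 10000 nM, which is a limit of the assay and not a number. In this assay compound 2 gives > 10000 nM, likewise a limit. In this assay compound 3 gives > 10000 nM, also a limit. Going by the values given here, compound 2 therefore stands at the limit of > 10000 nM in this assay, at which 3 of the 3 values shown sit, and there is no measured step by which to rank it against compound 1 or compound 3.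

Compound 4 `CCCNNC(=O)c1ccc(CNC(=O)c2cc3cc(Br)ccc3o2)cc1` is derived from compound 2 by bromo in place of allyloxy on an aromatic carbon. Among the compounds with values here, no step between measured compounds bears on this change, and every variant of that end of the molecule so far has ended at the same limit. The step that the limit leaves unreadable from compound 2 to compound 4 is expected to stay within the scatter, with no direction beyond it. Compound 4 is estimated at 20000 nM in this assay, with a range of 6000 nM to 70000 nM, and most probably it is again reported only as a limit.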

Compound 4, half-maximal inhibitory concentration: > 10000 nM
Compound 4 ended at the assay's limit; the forecaster's own chance of this, stated with the estimate: 85%; the middle value lies beyond the limit too.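

No step can be read from compound 2 to compound 4, as both values in this assay are limits of the assay and not numbers: the limit of > 10000 nM in this assay, at which 4 of the 4 values shown sit.

The compounds shown leave open whether any change at this end of the molecule gives a measurable value.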